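The source may report more compounds than this note shows. Statements on the series, on what has been measured and on what is new or still open speak of the compounds shown alone.

Compounds measured in a functional assay on DU-145 cells (Homo sapiens) for cytotoxicity, read by sulforhodamine B assay, with a stated time of 48 h; on this read-out lower numbers stand for stronger inhibition of growth and higher numbers for weaker inhibition of growth:
Compound 1 `Nc1nc(Cl)c2ncn(Cc3ccccc3CCl)c2n1` gives 32400 nM.
Compound 2 `ClCc1ccccc1Cn1cnc2nc(Cl)nc(Cl)c21` gives 3230 nM.
Compound 3 `ClCc1ccccc1Cn1cnc2ncnc(Cl)c21` gives 10200 nM.

Among these three, compound 1 stands at the highest number, with compound 3 nearest and compound 2 furthest away, each of those two gaps lying beyond the scatter. The unmeasured compound 4 `ClCc1ccccc1Cn1cnc2c(Cl)nc(Cl)nc21` is reached from compound 1 by a single change: chloro in place of amino on an aromatic carbon.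

For the measured compounds named here, no measured step covers this exact exchange. Going by the values given here, the one step that bears on it, a 3.2-fold higher number from compound 2 to compound 3 (0.50 log units; beyond the scatter), shows that taking a chloro group off an aromatic carbon of the core pushes the number up by a modest amount, so a chloro group on the core seems to favour a lower number in this assay. Like compound 4, compound 2 carries two chloro groups on the core, and compound 2 gives 3230 nM, the lowest number of the set. On this basis compound 4 is expected to sit well below compound 1, and the step of a 6.5-fold lower number from compound 1 to compound 4 (0.81 log units; beyond the scatter) is estimated to lie beyond the scatter in the direction of stronger inhibition. The value of compound 4 in this assay is therefore expected at about 5000 nM, within a range from 1500 nM to 16000 nM.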

Compound 4, concentration for total growth inhibition: 2950 nM
Estimate against measurement, compound 4: 1.7-fold (0.23 log units) above; the range from low to high includes it.
By their numbers in this assay, from the lowest: compounds 4 and 2 (each within the scatter of the next); then compound 3; then compound 1.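

In this assay, the exchange on the aromatic carbon between two ring nitrogen atoms gives an 11-fold lower number from compound 1 to compound 4 (1.04 log units; beyond the scatter), a large step that shows the number is sensitive to which of these two groups this carbon carries. The earlier step, a 3.2-fold higher number from compound 2 to compound 3 (0.50 log units; beyond the scatter), was modest and compared chloro only with hydrogen, so it said nothing about amino; the new step adds that, within this pair, amino on this carbon goes with a much higher number than chloro. Nothing available here gives a measured reason for the size of this step.

The compounds shown leave open how other groups on this same carbon would compare with chloro and amino, for example bromo, methoxy, methylamino or dimethylamino. They also leave open whether the amino-to-chloro step would keep its size if the chloromethyl group on the benzene ring were exchanged for a methyl or a hydroxymethyl group.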